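The source may hold more compounds than are shown below. What is called first, only, known or untested is meant among the compounds shown, and "the series" means these compounds.

In a functional assay on HeLa cells (Homo sapiens) for inhibition, read by MTT assay, with a stated time of 72 h (on this read-out higher numbers stand for weaker inhibition and lower numbers for stronger inhibition), compound 1 `COc1cc(OC)c(OC)cc1/C=C/C(=O)c1ccc(Cl)cc1` gives 36500 nM and compound 2 `COc1cc(OC)c(OC)cc1/C=C/C(=O)c1cc(Cc2ccccc2)cc(Cc2ccccc2)c1` gives 26900 nM. Going by the values given here, these two values lie within the usual scatter of each other, so compound 1 stands level with the only other compound measured. Compound 3 `COc1cc(OC)c(OC)cc1/C=C/C(=O)c1cc(Cl)ccc1O` carries 5-chloro-2-hydroxyphenyl in place of 4-chlorophenyl on a carbonyl carbon. Among the compounds with values here, no measured pair shows the effect of this change, so only a modest shift towards stronger inhibition is expected, with the estimated step being a 1.8-fold lower number from compound 1 to compound 3 (0.26 log units; within the scatter). In this assay, the estimated value for compound 3 is 20000 nM, with an expected range of 7000 nM to 50000 nM.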

Compound 3, half-maximal inhibitory concentration: > 150000 nM
Compound 3 ended at the assay's limit (the forecaster's own chance of this, stated with the estimate: 8%); middle value at least 7.5-fold (0.87 log units) away from the limit.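

At this place on a carbonyl carbon, the choice of ring matters: in this assay, putting 5-chloro-2-hydroxyphenyl in place of 4-chlorophenyl gives an at least 4.1-fold higher number from compound 1 to compound 3 (0.61 log units; beyond the scatter) and so clearly weaker inhibition. Compounds 1 and 2 differ in more than one place and stand level, so they gave no sign of such a loss. The reading for compound 3 is a limit of the assay, not a number: the limit of > 150000 nM in this assay, at which 1 of the 3 values shown sits.

Going by these compounds, the change alters the chloro position and adds a hydroxy group together, so the share of each in the loss stays open. On these data alone, whether a methoxy group or an amine in place of that hydroxy group would restore inhibition also stays open.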